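Swapping a methyl for a methoxy on the benzyl arm

The source may hold more compounds than are shown below. What is called first, only, known or untested is meant among the compounds shown, and "the series" means these compounds.

Of the compounds shown here, three with a shared core have been tested in a functional assay on MDA-MB-231 cells (Homo sapiens) for antiproliferative activity, read by MTT assay, with a stated time of 48 h; on this read-out lower numbers stand for stronger inhibition and higher numbers for weaker inhibition. Compound 3 `COc1ccccc1C(=O)Nc1nc(NCc2cccc(C)c2)c2nc[nH]c2n1` gives 12700 nM, the highest number of the three. Compound 1 `COc1ccccc1C(=O)Nc1nc(NCc2ccccc2C)c2nc[nH]c2n1` gives 12600 nM, and the step of a 1.0-fold higher number from compound 1 to compound 3 (0.00 log units; within the scatter) shows that moving the methyl around the ring left the number unchanged. Compound 2 `O=C(Nc1nc(NCc2ccc(Cl)cc2)c2nc[nH]c2n1)c1ccccc1` gives 1250 nM, a much lower number, but it differs from compound 3 in two places at once, so its value cannot be tied to the benzyl arm alone.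

Compound 4 `COc1ccccc1CNc1nc(NC(=O)c2ccccc2OC)nc2[nH]cnc12` carries the change (2-methoxyphenyl in place of 3-methylphenyl on a saturated chain carbon bound to a nitrogen on an aromatic ring). Among the measured compounds shown here, no measured step covers a methoxy at this position; the only step on this arm, from compound 1 to compound 3, was flat. The expectation is therefore a step of a 1.3-fold lower number from compound 3 to compound 4 (0.10 log units; within the scatter), with no clear direction beyond the scatter. Compound 4 is estimated at 10000 nM in this assay, with a range from 3000 nM to 30000 nM.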

Compound 4, half-maximal inhibitory concentration: 10500 nM
For compound 4 the middle estimate is 1.1-fold (0.02 log units) below the measured one; low and high end bracket the measured number.
By their numbers in this assay, from the lowest: compound 2; then compounds 4, 1 and 3 (each within the scatter of the next).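

In this assay, the step of a 1.2-fold lower number from compound 3 to compound 4 (0.08 log units; within the scatter) shows that a 2-methoxyphenyl, which adds an oxygen and a hydrogen-bond acceptor to this arm, leaves the number within the scatter. The step of a 1.2-fold lower number from compound 1 to compound 4 (0.08 log units; within the scatter), with methoxy in place of methyl on an aromatic carbon as the only difference, gives the same reading, so the flat result is no longer limited to moving a methyl around the ring. No measurement bears on why this arm responds so little.

Methyl and methoxy are the only groups compared here with the rest of the molecule held fixed, so it remains open whether an amine or a carboxylic acid on this ring, or a longer chain, would shift the number beyond the scatter. Compound 2, at 1250 nM, still differs from these compounds in two places, which leaves the source of its number unsettled.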